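This account rests on a few compounds, and the source may have more. Where it says the series, first, only, none or still open, it means among the compounds named here.

In a functional assay on OVCAR cells (Homo sapiens) for inhibition, read by MTT assay, with a stated time of 48 h (on this read-out lower numbers stand for stronger inhibition of growth and higher numbers for weaker inhibition of growth), the measured compounds gave:

Compound 1 `O=[N+]([O-])c1ccc(-c2cc(-c3ccccc3)n[nH]2)cc1`: 7200 nM
Compound 2 `O=[N+]([O-])c1ccc(-c2cc(-c3ccc(Br)cc3)n[nH]2)cc1`: 17500 nM
Compound 3 `COc1ccc(-c2cc(-c3ccccc3)n[nH]2)cc1`: 9900 nM

Compound 1 has the lowest number of the three; compound 3 lies within the scatter of it, whereas compound 2 sits further off, with a 2.4-fold higher number from compound 1 to compound 2 (0.39 log units; beyond the scatter). The change to compound 4 `O=[N+]([O-])c1ccc(-c2cc(-c3ccccc3-c3ccccc3)n[nH]2)cc1` is phenyl in place of hydrogen on an aromatic carbon. Among the measured compounds shown here, no measured step touches that position: the step of a 2.4-fold higher number from compound 1 to compound 2 (0.39 log units; beyond the scatter) concerns a bromo on the same ring, and a 1.4-fold higher number from compound 1 to compound 3 (0.14 log units; within the scatter) concerns the other ring. The only ring substitution seen so far weakened inhibition, so a modest rise in this assay is expected for compound 4, as a 1.7-fold higher number from compound 1 to compound 4 (0.22 log units; within the scatter). Compound 4 is therefore estimated at 12000 nM, with a range from 4000 nM to 40000 nM.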

Compound 4, concentration for 50% growth inhibition: 3400 nM
For compound 4 the middle estimate is 3.5-fold (0.55 log units) above the measured one, outside the stated range (below it).
By their numbers in this assay, from the lowest: compound 4; then compounds 1, 3 and 2 (each within the scatter of the next, the first and the last beyond it).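

In this assay, phenyl in place of hydrogen gives a 2.1-fold lower number from compound 1 to compound 4 (0.33 log units; beyond the scatter) and so shows that a group on this ring, ortho to a large group, can lower the number rather than raise it. The bromo on the same ring gave a 2.4-fold higher number from compound 1 to compound 2 (0.39 log units; beyond the scatter) and so went the opposite way, which means that substitution on this ring has no single direction across compounds 2 and 4. Nothing available explains this difference. The compounds shown leave open whether a methyl, an amine or a carboxylic acid on this same carbon would also lower the number. They also leave open whether phenyl would have the same effect with methoxy in place of the nitro.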